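Lengthening the isothiocyanate linker one carbon further

A few compounds are considered here, and "the series" means these few. Any claim that something is new, unique, unknown or untested is made for them only; others in the source may bear on it.

The series shares one core, carried by compound 2 `CN(C)C(=O)c1cc2cnc(Nc3ccc(C(=O)NCCCCCN=C=S)cc3F)nc2n1C1CCCC1` and by its shorter relative, compound 1 `CN(C)C(=O)c1cc2cnc(Nc3ccc(C(=O)NCCCN=C=S)cc3F)nc2n1C1CCCC1`. In a functional assay on NCI-H1299 cells (Homo sapiens) for inhibition, read by CCK-8 assay, with a stated time of 72 h, tested at 1 uM (on this read-out lower numbers stand for a weaker effect and higher numbers for a stronger effect at the one concentration tested), compound 1 gives 9.27%, while compound 2 gives 36.1%. For the measured compounds named here, that is a number 26.8 percentage points higher from compound 1 to compound 2 (beyond the scatter), and on these two numbers compound 2 stands highest, with compound 1 as its only neighbour.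

Compound 3 `CN(C)C(=O)c1cc2cnc(Nc3ccc(C(=O)NCCCCCCN=C=S)cc3F)nc2n1C1CCCC1` has not yet been measured. Its change from compound 2 is a group of 4 heavy atoms (2 carbon, 1 nitrogen, 1 sulfur; no ring) in place of a group of 3 heavy atoms (1 carbon, 1 nitrogen, 1 sulfur; no ring), on a saturated chain carbon, five bonds along the chain from an amide-type nitrogen. Going by the values given here, the only measured step that bears on it is the one from compound 1 to compound 2, and that step, a number 26.8 percentage points higher from compound 1 to compound 2 (beyond the scatter), went in the same direction as the present change, though it covered a larger change in the chain than the single added carbon here.

On that basis the step from compound 2 to compound 3 is expected to be small and upward, a number 7.9 percentage points higher from compound 2 to compound 3 (within the scatter), likely within the scatter. Compound 3 is estimated at 44% in this assay, with a range from 25% to 62%.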

Compound 3, a percentage reported as inhibition, at one concentration (the size of the read-out at that concentration, not a potency): 29.1%
Estimate against measurement, compound 3: 14.9 percentage points above; the range from low to high includes it.
By their numbers in this assay, from the lowest: compound 1; then compounds 3 and 2 (each within the scatter of the next).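

In this assay, the further extension at this position, a saturated chain carbon five bonds along the chain from an amide-type nitrogen, gives a number 7 percentage points lower from compound 2 to compound 3 (within the scatter) and so does not separate compound 3 from compound 2. The rise seen earlier in the series therefore does not visibly continue with the group of 4 heavy atoms in place of the group of 3 heavy atoms, although compound 3 still keeps clear of the shortest chain, with a number 19.8 percentage points higher from compound 1 to compound 3 (beyond the scatter) over the larger change at the position three bonds along the chain from the amide-type nitrogen. Across these compounds, the chain length of compound 1 is thus separated from the two longer chains, which cannot be told apart from each other here, and no measurement at hand accounts for this.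

From the compounds shown here alone, it remains open whether a longer chain than that of compound 3 would keep this level of inhibition or lose it, and whether an amine or a carboxylic acid in place of the isothiocyanate would retain any of it. Going by these compounds, with one concentration behind each number, whether compound 2 or compound 3 would give the stronger effect at any other concentration also stays open.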